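A Level Series Meets 4-Fluorophenyl

A few compounds are considered here, and "the series" means these few. Any claim that something is new, unique, unknown or untested is made for them only; others in the source may bear on it.

Of the compounds shown here, three sharing one core have been measured in a functional assay on HeLa cells (Homo sapiens) for cytotoxicity, read by WST assay, with a stated time of 48 h; a lower number here means a stronger inhibitor, a higher number a weaker inhibitor. There, compound 1 `COc1cccc(/C=C/C[C@H]2C[C@@H]([C@@H](O)c3ccccc3)CO[C@@H]2c2ccccc2)c1` gives 10900 nM, compound 2 `O[C@@H](c1ccccc1)[C@H]1CO[C@H](c2ccccc2)[C@@H](C/C=C/C2CCCC2)C1` gives 9330 nM and compound 3 `Cc1ccc(/C=C/C[C@H]2C[C@@H]([C@@H](O)c3ccccc3)CO[C@@H]2c2ccccc2)cc1C` gives 10000 nM. Compound 3 therefore stands level with the other two, inside the scatter of both, and the numbers set no order among the three.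

The next compound, compound 4 `O[C@@H](c1ccccc1)[C@H]1CO[C@H](c2ccccc2)[C@@H](C/C=C/c2ccc(F)cc2)C1`, keeps the core of compound 3 and alters one group: 4-fluorophenyl in place of 3,4-dimethylphenyl on a double-bonded chain carbon bound to a double-bonded chain carbon. Put plainly, 4-fluorophenyl takes the place of 3,4-dimethylphenyl on a double-bonded chain carbon bound to a double-bonded chain carbon.

All three measured steps were made at this same place, so they are the relevant guide. They read a 1.1-fold lower number from compound 1 to compound 3 (0.04 log units; within the scatter), a 1.1-fold higher number from compound 2 to compound 3 (0.03 log units; within the scatter) and a 1.2-fold lower number from compound 1 to compound 2 (0.07 log units; within the scatter), and each lies within the scatter. Among the measured compounds shown here, three groups at this place thus gave matching numbers, although no measured compound carries 4-fluorophenyl, so that group remains untested. On this evidence, no step beyond the scatter is expected in this assay, and no direction can be favoured.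

The estimated step is a 1.1-fold lower number from compound 3 to compound 4 (0.02 log units; within the scatter). For compound 4 the expected value is 9500 nM, with an estimated range of 5500 nM to 17000 nM.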

Compound 4, half-maximal inhibitory concentration: 8340 nM
Compound 4: the middle estimate sits 1.1-fold (0.06 log units) above what was measured; the range from low to high includes it.
By their numbers in this assay, from the lowest: compounds 4, 2, 3 and 1 (each within the scatter of the next).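

In this assay, among the compounds shown here, the place on a double-bonded chain carbon bound to a double-bonded chain carbon now holds 4-fluorophenyl, the only group that carries fluorine, and the outcome is level once more, with a 1.2-fold lower number from compound 3 to compound 4 (0.08 log units; within the scatter) and a 1.1-fold lower number from compound 2 to compound 4 (0.05 log units; within the scatter) and a 1.3-fold lower number from compound 1 to compound 4 (0.12 log units; within the scatter) all inside the scatter. This place has now taken cyclopentyl, 3-methoxyphenyl, 3,4-dimethylphenyl and 4-fluorophenyl on the shared core, and the numbers set no order among compound 1, compound 2, compound 3 and compound 4, so swapping in a fluorine-bearing group has not separated the series. There is no measured evidence on why the numbers stay level.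

All four groups are rings held on the same double-bonded chain, so the compounds shown leave open whether an amine, a carboxylic acid or a longer chain at this place would depart from these numbers. They also leave open whether the same level behaviour would hold if the shared core itself were changed.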